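The compounds below may be only part of what the source reports. "The series", "measured", "known", "first", "only" and "open" are said of these compounds alone.

Compound 1 `Nc1nc(-c2cc(N3C[C@H](O)[C@@H](O)C3)ccc2O)cc(C2CCCCCC2)n1` gives the lowest of the three numbers in a functional assay on EJ cells (Homo sapiens) for cytotoxicity, with a stated time of 48 h (a higher number here means a weaker inhibitor of growth, a lower number a stronger inhibitor of growth), with 700 nM. Compound 2 `Nc1nc(-c2cc(N3C[C@H](O)[C@@H](O)C3)ccc2O)cc(C2CCCCC2)n1` gives 1200 nM and compound 3 `CCc1cc(-c2cc(N3C[C@H](O)[C@@H](O)C3)ccc2O)nc(N)n1` gives 1500 nM. The change to compound 4 `Nc1nc(-c2cc(N3C[C@H](O)[C@@H](O)C3)ccc2O)cc(C2CCCC2)n1` is cyclopentyl in place of cycloheptyl on an aromatic carbon. For the measured compounds named here, the steps that bear on it replace the same group on the same aromatic carbon: a 1.7-fold higher number from compound 1 to compound 2 (0.23 log units; within the scatter) and a 2.1-fold higher number from compound 1 to compound 3 (0.33 log units; beyond the scatter), while a 1.3-fold higher number from compound 2 to compound 3 (0.10 log units; within the scatter). Going by the values given here, of the two steps from compound 1, only the one to compound 3 lies beyond the scatter. A modest rise in the number is therefore expected for compound 4 in this assay, of about a 1.9-fold higher number from compound 1 to compound 4 (0.27 log units; within the scatter). The estimate for compound 4 in this assay is 1300 nM, with a range from 600 nM to 2800 nM.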

Compound 4, concentration for 50% growth inhibition: 900 nM
Beside the measured number, compound 4's estimate is 1.4-fold (0.16 log units) above it; the range from low to high includes it.
By their numbers in this assay, from the lowest: compounds 1, 4, 2 and 3 (each within the scatter of the next, the first and the last beyond it).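

Cyclopentyl on this aromatic carbon stays within the scatter of every other group shown in this assay: a 1.3-fold higher number from compound 1 to compound 4 (0.11 log units; within the scatter) and a 1.3-fold lower number from compound 2 to compound 4 (0.12 log units; within the scatter) and a 1.7-fold lower number from compound 3 to compound 4 (0.22 log units; within the scatter). Cycloheptyl, cyclohexyl and cyclopentyl therefore show no readable order by ring size, and among the four compounds only the gap between compound 1 and compound 3 lies beyond the scatter. No measurement at hand speaks to the reason for this result. Open, going by these compounds, is whether an amine, a carboxylic acid or a longer chain on this carbon would stay in the same range.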